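Hydroxy in place of iodo on the fluorinated benzamide

The source may report more compounds than this note shows. Statements on the series, on what has been measured and on what is new or still open speak of the compounds shown alone.

Compound 1 `Fc1cccc(Cl)c1CNc1ccc(Oc2cc(C(F)(F)F)cc(C(F)(F)F)c2)cc1` reports only a limit, > 50000 nM.
Compound 2 `O=C(Nc1ccc(Oc2cc(C(F)(F)F)cc(C(F)(F)F)c2)cc1)c1ccccc1F` gives 3000 nM.
Compound 3 `O=C(Nc1ccc(Oc2cc(C(F)(F)F)cc(C(F)(F)F)c2)cc1)c1ccc(I)cc1F` reports only a limit, > 50000 nM.

In an assay on HEK293 cells for inhibition of Toll-like receptor 8 (Homo sapiens), with a stated time of 16 h (a lower number here means a stronger inhibitor, a higher number a weaker inhibitor), compound 3 stands at the limit and not at a number, as the limit of > 50000 nM in this assay, at which 2 of the 3 values shown sit, records. The next compound is compound 4 `O=C(Nc1ccc(Oc2cc(C(F)(F)F)cc(C(F)(F)F)c2)cc1)c1ccc(O)cc1F`, made by hydroxy in place of iodo on an aromatic carbon. Going by the values given here, the one measured step that touches this position is an at least 16-fold higher number from compound 2 to compound 3 (1.22 log units; beyond the scatter), where iodo entering cost a large amount. Removing iodo is therefore expected to regain much of that loss, while the incoming hydroxy has no precedent among the compounds shown, so the expected step of an at least 10-fold lower number from compound 3 to compound 4 (1.00 log units; beyond the scatter) is read with caution. Compound 4 is estimated at 5000 nM, in a range from 1500 nM to 50000 nM.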

Compound 4, half-maximal inhibitory concentration: > 50000 nM
Compound 4 was reported as a limit (the forecaster's own chance of this, stated with the estimate: 25%); middle value at least 10-fold (1.00 log units) away from the limit.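

In this assay, the step of an at least 16-fold higher number from compound 2 to compound 4 (1.22 log units; beyond the scatter) shows that the loss on filling this carbon, para to a large group, is not peculiar to iodo, since hydroxy in place of hydrogen also gives a large loss. The steps from compound 3 to compound 4 and from compound 1 to compound 4 cannot be read, as both ends of each are limits, so no order can be set among these compounds: the limit of > 50000 nM in this assay, at which 3 of the 4 values shown sit.

From the compounds shown here alone, it remains open whether methyl, methoxy or an amine at this carbon would keep the value of compound 2, 3000 nM. Going by these compounds, whether any group is accepted elsewhere on this ring also remains open.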